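A few compounds are considered here, and "the series" means these few. Any claim that something is new, unique, unknown or untested is made for them only; others in the source may bear on it.

Measured compounds in a functional assay on the whole organism (strain albino) for inhibition, with Rattus norvegicus as the target, read by paw edema, with stated times of 1 h and 2 h, at a dose of 20 mmol/kg by the intraperitoneal route; on this read-out higher numbers stand for more inhibition at the one dose given (going by the name of the read-out) and lower numbers for less inhibition:
- compound 1, `N#CC1=C(/N=C/Nc2ccc([N+](=O)[O-])cc2)N(c2ccccc2)C(=O)N2CCCCC(N3CCCC3)C12`: 41.5%
- compound 2, `N#CC1=C(/N=C/c2ccccc2)N(c2ccccc2)C(=O)N2CCCCC(N3CCCC3)C12`: 75.9%
- compound 3, `COc1ccc(/C=N/C2=C(C#N)C3C(N4CCCC4)CCCCN3C(=O)N2c2ccccc2)cc1`: 71.6%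

Compound 3 stands second of the three; the nearest step is a number 4.3 percentage points lower from compound 2 to compound 3 (within the scatter), within the scatter, while a number 30.1 percentage points higher from compound 1 to compound 3 (beyond the scatter) lies well beyond it. Compound 4, `COC(=O)C(=O)NC1=C(C#N)C2C(N3CCCC3)CCCCN2C(=O)N1c1ccccc1`, differs from compound 3 in this way: a group of 7 heavy atoms (3 carbon, 1 nitrogen, 3 oxygen; no ring) in place of a group of 10 heavy atoms (8 carbon, 1 nitrogen, 1 oxygen; one six-membered aromatic ring of carbon only), on a double-bonded ring carbon. Among the measured compounds shown here, no measured step swaps the aromatic group on the double-bonded ring carbon for a non-ring group bearing a hydrogen-bond donor. For the measured compounds named here, the nearest guide is a number 34.4 percentage points higher from compound 1 to compound 2 (beyond the scatter) together with a number 30.1 percentage points higher from compound 1 to compound 3 (beyond the scatter): the one compound carrying a nitrogen-bound donor at that position, compound 1, gives the lowest number. A step downward in this assay, beyond the scatter, is therefore expected, roughly a number 26.6 percentage points lower from compound 3 to compound 4 (beyond the scatter). Compound 4 is estimated at 45%, in the range 25% to 65%.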

Compound 4, a percentage reported as inhibition, in the whole organism at one dose (the size of the read-out at that dose, not a potency): 85.6%
Beside the measured number, compound 4's estimate is 40.6 percentage points below it; measured number above the stated range.
By their numbers in this assay, from the lowest: compound 1; then compounds 3, 2 and 4 (each within the scatter of the next, the first and the last beyond it).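

The step of a number 44.1 percentage points higher from compound 1 to compound 4 (beyond the scatter) and the step of a number 14 percentage points higher from compound 3 to compound 4 (beyond the scatter) show in this assay that a nitrogen-bound hydrogen-bond donor on the double-bonded ring carbon does not by itself go with a low number. With the step of a number 9.7 percentage points higher from compound 2 to compound 4 (within the scatter) as well, an aromatic ring in this group is not needed for a number in the range of compound 2. No measured data explain why ((methoxycarbonyl)carbonyl)amino and the group of compound 1 part so widely.

The compounds shown leave open whether the methyl ester end matters, which the carboxylic acid or a plain acetylamino group on the same carbon would test.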